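The compounds below may be only part of what the source reports. "The series", "measured", "known", "first", "only" and "open" are said of these compounds alone.

In a functional assay on HL-60 cells (Homo sapiens) for activation, read by flow cytometry, with a stated time of 4 days (a lower number here means that less compound is needed, a higher number that more compound is needed for the effect), compound 1 `Fc1ccc(-c2cc3c(cn2)ncn3-c2ccc(OC(F)F)cc2)cc1` gives 10000 nM, compound 2 `COc1cc(F)ccc1-c1cc2c(cn1)ncn2-c1ccc(OC(F)F)cc1` gives 93 nM and compound 3 `Fc1ccc(-c2cc3c(cn2)ncn3-c2ccc(OC(F)F)cc2)c(C(F)(F)F)c1` gives 1500 nM, the second highest of the three numbers, sitting a 6.7-fold lower number from compound 1 to compound 3 (0.82 log units; beyond the scatter) and a 16-fold higher number from compound 2 to compound 3 (1.21 log units; beyond the scatter). Compound 4 `CCCOc1cc(F)ccc1-c1cc2c(cn1)ncn2-c1ccc(OC(F)F)cc1` differs from compound 3 by propoxy in place of trifluoromethyl on an aromatic carbon. Among the compounds with values here, two measured steps bear on this change: a 110-fold lower number from compound 1 to compound 2 (2.03 log units; beyond the scatter) and a 16-fold higher number from compound 2 to compound 3 (1.21 log units; beyond the scatter), both large, and both point the same way, with a methoxy at this place giving the lowest number seen. Propoxy, like that methoxy, brings one oxygen to the same place, so the number for compound 4 is expected to drop by a 7.5-fold lower number from compound 3 to compound 4 (0.88 log units; beyond the scatter). Compound 4 is therefore estimated at 200 nM, within a range from 50 nM to 800 nM.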

Compound 4, half-maximal effective concentration: 58 nM
The estimate for compound 4 lay 3.4-fold (0.54 log units) above the measured number, and the stated range covers the measured number.
By their numbers in this assay, from the lowest: compounds 4 and 2 (each within the scatter of the next); then compound 3; then compound 1.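

In this assay, the longer chain on the oxygen leaves the number unchanged within the scatter, with a 1.6-fold lower number from compound 2 to compound 4 (0.21 log units; within the scatter), so this place tolerates propoxy as well as methoxy. Propoxy keeps the large advantage over hydrogen, with a 170-fold lower number from compound 1 to compound 4 (2.24 log units; beyond the scatter), and over trifluoromethyl, with a 26-fold lower number from compound 3 to compound 4 (1.41 log units; beyond the scatter). No measurement shown here gives a reason for these steps.

On these data alone, it remains open how a chain longer than propoxy would behave at this place. Also open, as far as these compounds go, is whether a group without oxygen, such as an amine or an ethyl group, would give a similarly low number.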